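Aryl substituent variation: methyl to chloro analogue

The source may report more compounds than this note shows. Statements on the series, on what has been measured and on what is new or still open speak of the compounds shown alone.

Compound 1, `C=C(Br)C(=O)Nc1cccc(-c2cn3nc(-c4ccc(F)cc4)sc3n2)c1`: 610 nM in a functional assay on FM3A cells (Mus musculus) for inhibition, read by cell counting, with a stated time of 2 days; a higher number here means a weaker inhibitor, a lower number a stronger inhibitor
Compound 2, `C=C(Br)C(=O)Nc1cccc(-c2cn3nc(-c4ccc(C)cc4)sc3n2)c1`: 1200 nM in this assay

Within the data shown here, compound 2 gives the highest of the two numbers so far, with compound 1 its only neighbour; the step of a 2.0-fold higher number from compound 1 to compound 2 (0.29 log units; within the scatter) lies within the scatter, so no order between the two can be claimed. Compound 3, `C=C(Br)C(=O)Nc1cccc(-c2cn3nc(-c4ccc(Cl)cc4)sc3n2)c1`, is not yet measured in this assay. It differs from compound 2 by chloro in place of methyl on an aromatic carbon. Among the measured compounds shown here, the only measured step, a 2.0-fold higher number from compound 1 to compound 2 (0.29 log units; within the scatter), concerns a different exchange on the same aromatic carbon and was within the scatter; nothing measured tests chloro against methyl directly. The expectation for compound 3 in this assay is therefore no step beyond the scatter, and the estimated step is a 1.3-fold lower number from compound 2 to compound 3 (0.12 log units; within the scatter). Compound 3 is estimated at 900 nM, within a range of 350 nM to 2500 nM.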

Compound 3, half-maximal inhibitory concentration: 2000 nM
Estimate against measurement, compound 3: 2.2-fold (0.35 log units) below, and the stated range covers the measured number.
By their numbers in this assay, from the lowest: compounds 1, 2 and 3 (each within the scatter of the next, the first and the last beyond it).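

In this assay, chloro in place of methyl gives a 1.7-fold higher number from compound 2 to compound 3 (0.22 log units; within the scatter), so this exchange does not separate the two compounds. Chloro in place of fluoro on the same aromatic carbon gives a 3.3-fold higher number from compound 1 to compound 3 (0.52 log units; beyond the scatter), a modest step but the first in the series to pass the scatter, so the group on this carbon, para to a large group, can shift the number, while compound 2 cannot be separated from either neighbour. Nothing available on these compounds accounts for the gap between fluoro and chloro.

Only fluoro, methyl and chloro are shown on this carbon, so it remains open how an amine, a carboxylic acid or a longer chain there would read. Also open, going by these compounds, is whether the step from fluoro to chloro holds when the rest of the molecule is changed.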